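A few compounds are considered here, and "the series" means these few. Any claim that something is new, unique, unknown or untested is made for them only; others in the source may bear on it.

In an ADME assay on microsomes from liver (Homo sapiens) for metabolic stability, with a stated time of 60 min, tested at 1 uM (on this read-out higher numbers stand for a more stable compound and lower numbers for a less stable compound), compound 1 `COc1cc(-c2cnn3cc(OC)c(C(C)C)nc23)ccn1` gives 40%. Compound 2 `COc1cn2ncc(-c3ccnc(OC(C)(C)C)c3)c2nc1-c1cnn(C)c1` gives 35%, a number within the usual scatter of compound 1. Compound 3 `Cn1cc(-c2nc3c(-c4ccnc(OC5CC5)c4)cnn3cc2OCC(C)(C)O)cn1` gives 53%, higher than compound 1 by more than that scatter. Compound 1 therefore stands level with compound 2 and under compound 3 on these three numbers.

Compound 4 `COc1cc(-c2cnn3cc(OC)c(N(C)C)nc23)ccn1` has not yet been measured. It differs from compound 1 in one place: dimethylamino in place of isopropyl on an aromatic carbon. In words, it carries dimethylamino in place of isopropyl on an aromatic carbon, and the rest of the structure stays the same.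

Among the measured compounds shown here, no two measured compounds differ by this swap, or by any other single change, so the data give no direct guide to its effect. The expectation starts from compound 1 at 40% and assumes no step beyond the scatter, with no firm direction. The estimated step is small, a number 2 percentage points higher from compound 1 to compound 4 (within the scatter). For compound 4 the expected value is 42%, with an estimated range from 20% to 65%.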

Compound 4, percent of the compound remaining: 16%
Beside the measured number, compound 4's estimate is 26 percentage points above it, outside the stated range (below it).
By their numbers in this assay, from the lowest: compound 4; then compounds 2 and 1 (each within the scatter of the next); then compound 3.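

Among the compounds shown here, the swap of isopropyl for dimethylamino is the first single change that can be read in this assay. Placed on an aromatic carbon next to the ring nitrogen and ortho to a methoxy group, dimethylamino gives a number 24 percentage points lower from compound 1 to compound 4 (beyond the scatter). This position therefore responds to what stands on it, even though the two groups have 3 heavy atoms each and differ in that one nitrogen replaces a carbon, adding one hydrogen-bond acceptor, and nothing measured here explains the step.

The compounds shown leave open how a plain amino group, a morpholine ring or a longer chain such as n-butyl would read at this place. They also leave open whether the same swap would give a similar step on another core.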